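Adding a Third Methyl to a Weak Antiproliferative Sulfone

A few compounds are considered here, and "the series" means these few. Any claim that something is new, unique, unknown or untested is made for them only; others in the source may bear on it.

Among the compounds with values here, compound 1 `COc1ccc(CS(=O)(=O)/C=C/c2ccc(C)cc2C)cc1` is the only member of this pair with a number: in a functional assay on H157 cells (Homo sapiens) for antiproliferative activity, read by trypan blue exclusion (a higher number here means a weaker inhibitor, a lower number a stronger inhibitor), compound 1 gives 15000 nM. Compound 2 `COc1ccc(CS(=O)(=O)/C=C/c2c(C)cccc2C)cc1` gives only a limit in this assay, > 20000 nM, so its true value is not known. Compound 2 therefore sits at the limit of > 20000 nM in this assay, at which 1 of the 2 values shown sits, the weak end of what is shown. Compound 3 `COc1ccc(CS(=O)(=O)/C=C/c2c(C)cc(C)cc2C)cc1` differs from compound 2 by methyl in place of hydrogen on an aromatic carbon. Within the data shown here, no measured step covers this change, so compound 3 is expected to remain weak, with a step of a number no higher from compound 2 to compound 3 (the limit leaves the size open) expected. Compound 3 is estimated at 20000 nM, within 8000 nM to 50000 nM.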

Compound 3, half-maximal inhibitory concentration: > 20000 nM
Compound 3: no number, only a limit; the forecaster's own chance of this, stated with the estimate: 60%; the middle value lies on the limit itself.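

Putting a methyl at this position, para to a large group, yields no measurable number in this assay, and compound 3 joins compound 2 at the limit of the assay: the limit of > 20000 nM in this assay, at which 2 of the 3 values shown sit. The step between these two limits cannot be read. The comparison with the one measured compound gives an at least 1.3-fold higher number from compound 1 to compound 3 (0.12 log units; that floor lies within the scatter), so only a floor is known and no real loss is shown.

From the compounds shown here alone, how far compound 2 and compound 3 lie past the limit stays open. So does whether an amine or a carboxylic acid at this position would give a measurable number.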